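This account rests on a few compounds, and the source may have more. Where it says the series, first, only, none or still open, it means among the compounds named here.

In a physicochemical assay for lipophilicity, using the shake flask method, measured as octanol-water partition, at pH 7.4 (on this read-out higher numbers stand for higher lipophilicity and lower numbers for lower lipophilicity), measured so far:

Compound 1 `CC(=O)N[C@@H]1CCC[C@H](C(=O)Nc2cc(-c3cnn4c3CCCC4)c(Cl)cn2)C1`: 3.2
Compound 2 `CC(=O)N[C@@H]1CCC[C@H](C(=O)Nc2cc(-c3nnn4ccccc34)c(Cl)cn2)C1`: 2
Compound 3 `CC(=O)N[C@@H]1CCC[C@H](C(=O)Nc2cc(-c3cnn4c3CCC4)c(Cl)cn2)C1`: 2.9

The next change starts from compound 3, which sits in the upper pair of the series. Its two steps are a number 0.30 log units lower from compound 1 to compound 3 (within the scatter) and a number 0.90 log units higher from compound 2 to compound 3 (beyond the scatter).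

Compound 4 `CC(=O)N[C@@H]1CCC[C@H](C(=O)Nc2cc(-c3cnn4c3COCC4)c(Cl)cn2)C1` carries this change: a group of 9 heavy atoms (6 carbon, 2 nitrogen, 1 oxygen; one five-membered aromatic ring with 2 hetero atoms, one six-membered non-aromatic ring with 2 hetero atoms) in place of a group of 8 heavy atoms (6 carbon, 2 nitrogen; one five-membered non-aromatic ring with 1 hetero atom, one five-membered aromatic ring with 2 hetero atoms), on an aromatic carbon. The group sits ortho to a chloro group and opposite the ring nitrogen.

For the measured compounds named here, two measured steps bear on this. Going from a six-membered to a five-membered non-aromatic ring gave only a number 0.30 log units lower from compound 1 to compound 3 (within the scatter), so ring size alone offers little guidance. Compound 2 is the only measured case with more hetero atoms in this group, and it gave a number 1.20 log units lower from compound 1 to compound 2 (beyond the scatter). On that single precedent a lower number is expected, though a smaller drop, since the aromatic rings of compound 2 do not recur here.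

In this assay the expected step is a number 0.60 log units lower from compound 3 to compound 4 (beyond the scatter). The estimate for compound 4 is 2.3, with an expected range from 1.8 to 2.8.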

Compound 4, distribution coefficient: 2.4
Compound 4: middle estimate off by 0.10 log units, on the low side, and the stated range covers the measured number.
By their numbers in this assay, from the lowest: compound 2; then compound 4; then compounds 3 and 1 (each within the scatter of the next).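

In this assay, for the compounds shown here, on this aromatic carbon ortho to a chloro group, compound 4 gives the first comparison at a fixed ring size, with one carbon of the six-membered non-aromatic ring exchanged for oxygen: a number 0.80 log units lower from compound 1 to compound 4 (beyond the scatter). Against the five-membered ring, where ring size and atom type change together, the step is a number 0.50 log units lower from compound 3 to compound 4 (beyond the scatter), so the oxygen-bearing ring moves this read-out further than the ring-size step alone did, while keeping clear of the bicyclic aromatic group: a number 0.40 log units higher from compound 2 to compound 4 (beyond the scatter). Nothing measured here accounts for these steps.

Still open is whether the oxygen's place within the ring matters, as the compounds shown carry it at a single place. Also open, going by these compounds, is whether an amine in that ring, or a hydroxyl on the all-carbon ring of compound 1, would give a step of similar size.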